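Ethoxycarbonyl to Methylpyrazolyl: What to Expect of Compound 3

This account rests on a few compounds, and the source may have more. Where it says the series, first, only, none or still open, it means among the compounds named here.

Compound 1 `Cc1cc(CO)nc(NNC(=O)Nc2cc(Cl)nc(Cl)c2)c1`: 31 nM
Compound 2 `CCOC(=O)c1cc(C)cc(NNC(=O)Nc2cc(Cl)nc(Cl)c2)n1`: 2.1 nM

Both compounds share one core and differ only in the group on the aromatic carbon beside the large urea-bearing arm. In a functional assay on CHO cells for antagonist activity at sphingosine 1-phosphate receptor 2 (Homo sapiens), read by scintillation counting and GTPgammaS binding, with a stated time of 4 h, in the presence of a further agent that is not named here (a higher number here means a weaker inhibitor, a lower number a stronger inhibitor), compound 1 gives 31 nM, while compound 2 gives 2.1 nM. For the measured compounds named here, compound 2 thus stands at the lowest number of the two, and the single measured step, a 15-fold lower number from compound 1 to compound 2 (1.17 log units; beyond the scatter), shows that exchanging the hydroxymethyl for an ethoxycarbonyl at that carbon brought a large gain.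

Compound 3 `Cc1cc(NNC(=O)Nc2cc(Cl)nc(Cl)c2)nc(-c2cnn(C)c2)c1` keeps everything of compound 2 except that same position: 1-methyl-1H-pyrazol-4-yl in place of ethoxycarbonyl on an aromatic carbon. No measured step involves a pyrazole, so the only guide is that this carbon has already shown itself sensitive to what sits on it, as the step from hydroxymethyl to ethoxycarbonyl was large. A flat, aromatic ring bearing two acceptors is a different kind of group from an ester, and the direction cannot be read from the data.

For compound 3 the number is expected to sit somewhat above that of compound 2, an estimated 8 nM with a likely range of 2 nM to 40 nM. That would mean an expected step of a 3.8-fold higher number from compound 2 to compound 3 (0.58 log units; beyond the scatter).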

Compound 3, half-maximal inhibitory concentration: 3.1 nM
Compound 3: middle estimate off by 2.6-fold (0.41 log units), on the high side, and the stated range covers the measured number.
By their numbers in this assay, from the lowest: compounds 2 and 3 (each within the scatter of the next); then compound 1.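

The swap of ethoxycarbonyl for 1-methyl-1H-pyrazol-4-yl gives a 1.5-fold higher number from compound 2 to compound 3 (0.17 log units; within the scatter) in this assay, so at this carbon, on a six-membered aromatic ring and next to the ring nitrogen, the two groups cannot be told apart. The result was not tied to the ester: an open group with no ring and a five-membered aromatic ring with two hetero atoms both fit here, and the pyrazole also shows a 10-fold lower number from compound 1 to compound 3 (1.00 log units; beyond the scatter), a clear gain over hydroxymethyl. No measurement shown here explains why two such different groups give matching numbers at this carbon.

From the compounds shown here alone, it remains open whether other groups at this carbon, such as a phenyl ring, a primary amide or a carboxylic acid, would match compound 2 and compound 3 or fall back towards compound 1. It is also unknown what the methyl on the pyrazole contributes, which a pyrazole without that methyl, or with an ethyl in its place, would help to answer.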